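This account rests on a few compounds, and the source may have more. Where it says the series, first, only, none or still open, it means among the compounds named here.

In an ADME assay on Vero cells (Chlorocebus sabaeus) for cytotoxicity, read by crystal violet staining (a lower number here means that less compound is tolerated, a higher number that more compound is tolerated), compound 1 `c1ccc(/N=N/N2CCN(c3ccccc3)CC2)cc1` gives >= 100000 nM, which is a limit of the assay and not a number. Two other compounds give actual numbers: compound 2 `CN(C)CCCN(/N=N/c1c(F)cccc1F)c1ccccc1` gives 25000 nM, and compound 3 `Fc1ccc(F)c(/N=N/Nc2ccccc2)c1` gives 80000 nM. Still unmeasured is compound 4 `c1ccc(/N=N/N2CCN(c3ncccn3)CC2)cc1`, which carries pyrimidin-2-yl in place of phenyl on an amine nitrogen in a ring. Among the measured compounds shown here, no measured pair shows this swap, so any forecast is uncertain. Little change is expected, perhaps a small move towards lower numbers, since even compound 3 at 80000 nM is well tolerated. The expected size of the change is an at least 1.1-fold lower number from compound 1 to compound 4 (0.07 log units; that floor lies within the scatter). For compound 4 the estimated value is 85000 nM, with an expected range from 35000 nM to 100000 nM.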

Compound 4, half-maximal cytotoxic concentration: 65000 nM
Compound 4: middle estimate off by 1.3-fold (0.12 log units), on the high side; low and high end bracket the measured number.
By their numbers in this assay, from the lowest: compound 2; then compounds 4 and 3 (each within the scatter of the next). At a limit, above all of these: compound 1.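

In this assay, among the compounds shown here, pyrimidin-2-yl in place of phenyl on an amine nitrogen in a ring gives an at least 1.5-fold lower number from compound 1 to compound 4 (0.18 log units; that floor lies within the scatter) as the first direct reading of a change at this position. The two added ring nitrogens therefore leave a measurable number on the low side of the limit, though this floor alone does not establish a real change. From the compounds shown here alone, the full size of the step stays unknown because compound 1 stands at a limit: the limit of >= 100000 nM in this assay, at which 1 of the 4 values shown sits. Going by these compounds, whether a pyridin-2-yl or benzyl group on that ring nitrogen would be tolerated as well remains open.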